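A Methyl-to-Ethyl Step at the Low End

This account rests on a few compounds, and the source may have more. Where it says the series, first, only, none or still open, it means among the compounds named here.

Values in a functional assay on the whole organism (Abdomen) with Mus musculus as the target (a lower number here means that less compound is needed, a higher number that more compound is needed for the effect), stand as follows:
- Compound 1 `Cc1nc(Cc2c[nH]cn2)c(C)o1` gives > 30 mg/kg as a limit of the assay and not a number
- Compound 2 `CCc1sc(-c2ccccc2)nc1Cc1c[nH]cn1` gives 15 mg/kg
- Compound 3 `Cc1nc(Cc2c[nH]cn2)sc1C` gives 1.7 mg/kg

Compound 3 at 1.7 mg/kg holds the lowest of the two numbers available. Its nearest neighbour is compound 2 at 15 mg/kg with a higher number, and that gap lies beyond the scatter. Compound 1 offers only its limit and so cannot be placed exactly.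

Compound 4 `CCc1nc(Cc2c[nH]cn2)sc1C` differs from compound 3 by a single change (methyl in place of hydrogen on a saturated chain carbon bound to an aromatic carbon): methyl in place of hydrogen on a saturated chain carbon bound to an aromatic carbon, which reads as methyl to ethyl. For the measured compounds named here, no measured pair of compounds differs in just one place, so no direct precedent exists for this change. Compound 2 at 15 mg/kg also bears an ethyl group, but it differs from compound 3 in more than that one respect and gives only loose guidance. In this assay a small shift towards a higher number is expected, a 1.5-fold higher number from compound 3 to compound 4 (0.17 log units; within the scatter) and likely no larger than the scatter. For compound 4 the estimated value is 2.5 mg/kg with an expected range from 0.7 mg/kg to 9 mg/kg in this measurement.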

Compound 4, dose for half-maximal effect: > 30 mg/kg
Compound 4: a limit, no number; the forecaster's own chance of this, stated with the estimate: 7%; middle value at least 12-fold (1.07 log units) away from the limit.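

In this assay, the change from methyl to ethyl proves to be a large one: an at least 17-fold higher number from compound 3 to compound 4 (1.24 log units; beyond the scatter). Before this result no two compounds differed in just one place, so this is the first direct reading of this position, and it shows that a single added carbon on a saturated chain carbon bound to an aromatic carbon is enough to carry the compound out of the measurable range. On these data alone, compound 4 gives > 30 mg/kg, which is a limit of the assay and not a number, so the step can be read only as a minimum and its true size stays unknown: the limit of > 30 mg/kg in this assay, at which 2 of the 4 values shown sit.

The compounds shown leave open whether a longer chain such as propyl would behave like ethyl here, and whether a hydroxymethyl group or an amine on this carbon would keep the value that compound 3 gives, 1.7 mg/kg. They also leave open whether the same change would have so large a step on the core of compound 1 or of compound 2, as neither has a partner differing from it in this one place.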